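A few compounds are considered here, and "the series" means these few. Any claim that something is new, unique, unknown or untested is made for them only; others in the source may bear on it.

Measured so far:
compound 1, `CCOc1cc(C(=CC#N)c2ccc(OC)c(F)c2)ccc1OC`: 130 nM
compound 2, `CCOc1cc(C(=CC#N)c2cccc(OC)c2)ccc1OC`: 450 nM
compound 3, `COc1cc(OC)cc(C(=CCCN(C)C)c2ccc(OC)c(OC)c2)c1`: > 10000 nM

Of the compounds shown here, three have been tested in a functional assay on HCT-116 cells (Homo sapiens) for cytotoxicity, read by scintillation counting and thymidine incorporation, with a stated time of 72 h; on this read-out lower numbers stand for stronger inhibition and higher numbers for weaker inhibition. Compound 1 gives 130 nM and compound 2 gives 450 nM. Compound 3 reaches only the limit of the assay, > 10000 nM, and this is a limit rather than a number. Compound 3 therefore stands at the limit of > 10000 nM in this assay, at which 1 of the 3 values shown sits, the far end of the numbers shown, well apart from the other two.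

Compound 4 `CCC=C(c1cc(OC)cc(OC)c1)c1ccc(OC)c(OC)c1` has not yet been measured. It differs from compound 3 in one place: hydrogen in place of dimethylamino on a saturated chain carbon, two bonds along the chain from a double-bonded chain carbon. Within the data shown here, no two of the measured compounds differ from each other in a single place, so no measured step speaks directly to this change, and the two active compounds share little with compound 4 beyond the general layout of their cores.

Because compound 3 sits at the limit of > 10000 nM in this assay, at which 1 of the 3 values shown sits, the step from compound 3 to compound 4 in this assay can only be read as downward or as none, and the step expected here is an at least 1.2-fold lower number from compound 3 to compound 4 (0.09 log units; that floor lies within the scatter), not beyond the scatter. Compound 4 is accordingly estimated at 8000 nM, within a range from 1500 nM to 50000 nM, with a fair chance that only a limit is reported once more.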

Compound 4, half-maximal inhibitory concentration: > 10000 nM
Compound 4 gave a limit, no number; the forecaster's own chance of this, stated with the estimate: 55%; middle value at least 1.2-fold (0.09 log units) from the limit.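

In this assay, compound 4, like compound 3, stands at a limit and not at a number, so no step between these two compounds can be read: the limit of > 10000 nM in this assay, at which 2 of the 4 values shown sit.

The compounds shown leave open whether hydrogen in place of dimethylamino on the chain changes the read-out at all, as neither compound offers a number to compare.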